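Amino in place of hydrogen on the sulfonyl ring

A few compounds are considered here, and "the series" means these few. Any claim that something is new, unique, unknown or untested is made for them only; others in the source may bear on it.

Measured so far in an assay on OCI-Ly3 cells for activation of NF-kappa-B inhibitor alpha (Homo sapiens), read by a luciferase reporter; on this read-out lower numbers stand for an effect already at smaller amounts and higher numbers for an effect only at larger amounts of compound:
compound 1, `Cc1ccc2cccc(NS(=O)(=O)c3ccc(C(F)(F)F)cc3[N+](=O)[O-])c2n1`, 3600 nM
compound 2, `COc1cc(NS(=O)(=O)c2ccc(C)cc2[N+](=O)[O-])c2nc(C)ccc2c1`, a limit of the assay, > 57000 nM
compound 3, `COc1cc(NS(=O)(=O)c2ccc(C)cc2)c2nc(C)ccc2c1`, 20000 nM

Compound 3 gives the highest of the two numbers; the nearest is compound 1, which sits beyond the scatter below it. For compound 2 only a limit is known (the limit of > 57000 nM in this assay, at which 1 of the 3 values shown sits). Compound 4, `COc1cc(NS(=O)(=O)c2ccc(C)cc2N)c2nc(C)ccc2c1`, is not yet measured. It differs from compound 3 by amino in place of hydrogen on an aromatic carbon.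

For the measured compounds named here, one measured step touches the same aromatic carbon: an at least 2.8-fold lower number from compound 2 to compound 3 (0.45 log units; beyond the scatter), hydrogen in place of nitro. Nothing measured reads on an amino group there. Given the loss recorded from compound 2 to compound 3 when a group occupied that carbon, a new substituent at the same place is expected, by estimate, to cost a little or to leave the number roughly where compound 3 stands, and the limit of the assay is a real possibility. Compound 4 is therefore expected to give 30000 nM, with a range of 9000 nM to 100000 nM, an estimated step of a 1.5-fold higher number from compound 3 to compound 4 (0.18 log units; within the scatter).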

Compound 4, half-maximal effective concentration: 3000 nM
Estimate against measurement, compound 4: 10-fold (1.00 log units) above; the measured number lies below the stated range.
By their numbers in this assay, from the lowest: compounds 4 and 1 (each within the scatter of the next); then compound 3. At a limit, above all of these: compound 2.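

In this assay, the outcome at the aromatic carbon ortho to a large group depends on which group sits there, not on whether the carbon is occupied: amino in place of hydrogen gives a 6.7-fold lower number from compound 3 to compound 4 (0.82 log units; beyond the scatter), so a substituent there can lower the number as well as raise it, as nitro does in an at least 2.8-fold lower number from compound 2 to compound 3 (0.45 log units; beyond the scatter). Amino in place of nitro on that carbon gives an at least 19-fold lower number from compound 2 to compound 4 (1.27 log units; beyond the scatter). Compound 2 stands at a limit, so this step is a bound and not an exact size: the limit of > 57000 nM in this assay, at which 1 of the 4 values shown sits.

What sets amino apart from nitro at this carbon cannot be told from these compounds. Also open, from the compounds shown here alone, are whether hydroxyl, methylamino or acetylamino there would track amino or nitro, and whether amino in place of nitro has a similar effect on the core of compound 1.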